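Chain Homologation and Half-Life: Working Notes

The source may report more compounds than this note shows. Statements on the series, on what has been measured and on what is new or still open speak of the compounds shown alone.

Compound 1 `CCCCCCCNC(=O)Oc1ccc(Cl)cc1C(=O)Nc1ccc(Cl)cc1` carries the shortest chain in the set. In an ADME assay for metabolic stability, read by HPLC, at pH 7.4 (on this read-out lower numbers stand for a shorter-lived compound and higher numbers for a longer-lived compound), compound 1 gives 43 h. Compound 2 `CCCCCCCCNC(=O)Oc1ccc(Cl)cc1C(=O)Nc1ccc(Cl)cc1` differs from compound 1 by methyl in place of hydrogen on a saturated chain carbon, seven bonds along the chain from an amide-type nitrogen; in this assay compound 2 gives 43 h, and the step is no change at the digits printed from compound 1 to compound 2 (within the scatter). Compound 3 `CCCCCCCCNC(=O)Oc1ccc(Cl)cc1C(=O)Nc1ccc(Cl)c(Cl)c1` carries chloro in place of hydrogen on an aromatic carbon relative to compound 2; in this assay compound 3 gives 43 h, and the step is no change at the digits printed from compound 2 to compound 3 (within the scatter). The difference between the core of compound 1 and the core of compound 3 is not broken down here. All three measured values stand level with one another, so nothing in the set so far moves the read-out.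

Compound 4 `CCCCCCCCCNC(=O)Oc1ccc(Cl)cc1C(=O)Nc1ccc(Cl)c(Cl)c1` is not yet measured. It differs from compound 3 by methyl in place of hydrogen on a saturated chain carbon, eight bonds along the chain from an amide-type nitrogen. Within the data shown here, this is the same kind of change as the one from compound 1 to compound 2, not the same change: in both cases methyl replaces hydrogen on a saturated chain carbon, but in the earlier case that carbon sits seven bonds along the chain from an amide-type nitrogen, whereas here it sits eight bonds along the chain from an amide-type nitrogen. The earlier instance gave no change at the digits printed from compound 1 to compound 2 (within the scatter).

The step expected here is no change at the digits printed from compound 3 to compound 4 (within the scatter). This rests on the earlier instance, no change at the digits printed from compound 1 to compound 2 (within the scatter), and on the flat run across compounds 1, 2 and 3. Compound 4 is therefore estimated at 43 h in this assay, with an expected range from 24 h to 78 h.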

Compound 4, half-life: 43 h
Compound 4: the middle estimate sits on the measured number at the digits printed; measured number inside the range.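

In this assay the newest step, methyl in place of hydrogen on a saturated chain carbon, eight bonds along the chain from an amide-type nitrogen, reads no change at the digits printed from compound 3 to compound 4 (within the scatter) and agrees with the earlier instance of this kind of change: the same change on two cores in this assay, no change at the digits printed (within the scatter) from compound 1 to compound 2 and no change at the digits printed (within the scatter) from compound 3 to compound 4, 1.0-fold (0.00 log units) apart, within the scatter of two such steps

Within these four compounds, then, lengthening the chain by this one carbon carries from the core of compound 1 to the core of compound 3 with the half-life left level, even though the carbon that takes the methyl sits seven bonds along the chain in one case and eight in the other. This does not show why the half-life stays level, and two flat steps in a single assay offer no size of effect to transfer and no assurance that the change would behave the same way on any other core.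

The compounds shown leave open whether a longer chain, a branched chain or a chain ending in an amine or a carboxylic acid would shift the half-life at all. They also leave open what a fluoro or methoxy group in place of chloro on the aromatic carbons would do on the shared core.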